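The source may report more compounds than this note shows. Statements on the series, on what has been measured and on what is new or still open speak of the compounds shown alone.

Compound 1 `COc1ccc2c(=O)c(/C=C/C(=O)Nc3cccc(Cl)c3)coc2c1` sits at the limit of this assay, > 100000 nM in a functional assay (QGY7701 cells, Homo sapiens) for inhibition, read by MTT assay, with a stated time of 48 h (a higher number here means a weaker inhibitor, a lower number a stronger inhibitor), a limit rather than a number. Compound 2 `COc1ccc2c(=O)c(/C=C/C(=O)Nc3ccccc3)coc2c1` gives 14000 nM. Compound 3 `COc1cccc(NC(=O)/C=C/c2coc3cc(OC)ccc3c2=O)c1` gives 39100 nM.

Compound 1 stands at the limit (the limit of > 100000 nM in this assay, at which 1 of the 3 values shown sits), so only a bound is known for it. Compound 4 `COc1ccc2c(=O)c(/C=C/C(=O)NCc3cccc(F)c3)coc2c1` differs from it by a single change: 3-fluorobenzyl in place of 3-chlorophenyl on an amide-type nitrogen. Going by the values given here, no measured step swaps an aryl for a benzyl on the amide nitrogen, but both measured steps leaving compound 1 remove the chloro and lower the number: an at least 7.1-fold lower number from compound 1 to compound 2 (0.85 log units; beyond the scatter) and an at least 2.5-fold lower number from compound 1 to compound 3 (0.40 log units; beyond the scatter). Compound 4 is therefore expected to fall below the limit, with a step of an at least 3.3-fold lower number from compound 1 to compound 4 (0.52 log units; beyond the scatter). The estimate for compound 4 is 30000 nM, between 8000 nM and 150000 nM.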

Compound 4, half-maximal inhibitory concentration: 28600 nM
The estimate for compound 4 lay 1.0-fold (0.02 log units) above the measured number; measured number inside the range.
By their numbers in this assay, from the lowest: compound 2; then compounds 4 and 3 (each within the scatter of the next). At a limit, above all of these: compound 1.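

Replacing 3-chlorophenyl with 3-fluorobenzyl on the amide-type nitrogen gives an at least 3.4-fold lower number from compound 1 to compound 4 (0.54 log units; beyond the scatter), a step that is itself only a bound: the limit of > 100000 nM in this assay, at which 1 of the 4 values shown sits. In this assay, replacing 3-methoxyphenyl with 3-fluorobenzyl gives a 1.4-fold lower number from compound 3 to compound 4 (0.14 log units; within the scatter), so the benzyl and this aryl group cannot be told apart here. Replacing phenyl with 3-fluorobenzyl gives a 2.0-fold higher number from compound 2 to compound 4 (0.31 log units; beyond the scatter), so compound 4 keeps a measurable number without matching compound 2.

From the compounds shown here alone, how much of this belongs to the fluoro and how much to the added carbon stays open. So does what a plain benzyl or a phenylethyl chain on this nitrogen would give.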